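What a 2,4-dichlorophenyl group may do to compound 2

The compounds below may be only part of what the source reports. "The series", "measured", "known", "first", "only" and "open" are said of these compounds alone.

- Compound 1 `O=C(Cc1csc2nc(-c3ccc(Br)cc3)cn12)N/N=C/c1ccccc1O`: 12900 nM
- Compound 2 `COc1cccc(OC)c1/C=N/NC(=O)Cc1csc2nc(-c3ccc(Br)cc3)cn12`: 57500 nM

In a functional assay on SK-OV-3 cells (Homo sapiens) for inhibition, read by sulforhodamine B assay, with a stated time of 48 h (on this read-out higher numbers stand for weaker inhibition of growth and lower numbers for stronger inhibition of growth), compound 2 gives 57500 nM, the higher of the two numbers and so the weaker growth inhibition. Compound 3 `O=C(Cc1csc2nc(-c3ccc(Br)cc3)cn12)N/N=C/c1ccc(Cl)cc1Cl` changes one group: 2,4-dichlorophenyl in place of 2,6-dimethoxyphenyl on a carbon with a double bond to nitrogen. Among the measured compounds shown here, the only measured step at this place is a 4.5-fold higher number from compound 1 to compound 2 (0.65 log units; beyond the scatter), which is modest but beyond the scatter. It shows that this group can shift the number. For the measured compounds named here, no measured compound carries the 2,4-dichlorophenyl group, so a partial return towards compound 1 is only a cautious expectation. The expected change is a 2.6-fold lower number from compound 2 to compound 3 (0.42 log units; beyond the scatter). For compound 3, the estimated value is 22000 nM, with an expected range of 7000 nM to 70000 nM.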

Compound 3, concentration for 50% growth inhibition: < 100000 nM
Compound 3 was reported as a limit (the forecaster's own chance of this, stated with the estimate: 15%); the middle value does not contradict the limit.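

In this assay compound 3 gives only a limit, < 100000 nM. Its steps from compound 1 and compound 2 therefore cannot be read. As far as these compounds go, whether 2,4-dichlorophenyl gives stronger or weaker growth inhibition than either replaced group stays open.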